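A few compounds are considered here, and "the series" means these few. Any claim that something is new, unique, unknown or untested is made for them only; others in the source may bear on it.

Notes on the series built on the shared core of compound 1 `O=C(CCc1cccc2c1B(O)OC2)NC1CCCCC1`. In a functional assay on SK-OV-3 cells (Homo sapiens) for antiproliferative activity, read by MTT assay, with a stated time of 72 h (on this read-out higher numbers stand for weaker inhibition and lower numbers for stronger inhibition), compound 1 gives only a limit, > 100000 nM, and no number; where compound 1 stands among the values shown is known only to that extent (the limit of > 100000 nM in this assay, at which 1 of the 2 values shown sits). Compound 2 `CC(C)(C)c1ccc(NC(=O)CCc2cccc3c2B(O)OC3)cc1`, which carries an aromatic ring on the amide-type nitrogen, gives 4200 nM in this assay. Compound 3 `O=C(CCc1cccc2c1B(O)OC2)Nc1cccc(I)c1` is not yet measured; it differs from compound 1 by 3-iodophenyl in place of cyclohexyl on an amide-type nitrogen, so compound 3 also places an aromatic ring on the amide-type nitrogen where compound 1 has cyclohexyl. Since compound 1 yields only a limit, no measured step sizes this change. Compound 2, with its aromatic ring at that nitrogen, gives 4200 nM, and on that ground the step of an at least 16-fold lower number from compound 1 to compound 3 (1.22 log units; beyond the scatter) is expected to be a gain beyond the scatter. The estimate for compound 3 in this assay is 6000 nM, with a range from 1500 nM to 40000 nM.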

Compound 3, half-maximal inhibitory concentration: 630 nM
Beside the measured number, compound 3's estimate is 9.5-fold (0.98 log units) above it; measured number outside the range, below it.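

For the compounds shown here, at the amide-type nitrogen, 3-iodophenyl in place of cyclohexyl gives an at least 150-fold lower number from compound 1 to compound 3 (2.20 log units; beyond the scatter) in this assay, the first step at this place that carries a size. Two aromatic groups on this nitrogen now give numbers, and these are not the same: compound 2 gives 4200 nM and compound 3 gives 630 nM, so the printed values show that the group on the aromatic ring also matters here. Compound 1 gives a limit and not a number, so the full size of the step stays unknown: the limit of > 100000 nM in this assay, at which 1 of the 3 values shown sits.

As far as these compounds go, how an unsubstituted phenyl or a 3-chlorophenyl on this nitrogen would compare with 3-iodophenyl stays open, and with it the share of the iodine in the result. Also open, from the compounds shown here alone, is what a benzyl group or a longer chain ending in a phenyl ring would give at this place.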